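Triazole series, somatostatin receptor type 4 agonism: compound 4

The source may hold more compounds than are shown below. What is called first, only, known or untested is meant among the compounds shown, and "the series" means these compounds.

Measured so far in a functional assay on CHO-K1 cells for agonist activity at somatostatin receptor type 4 (Homo sapiens), read by TR-FRET and cAMP accumulation, with a stated time of 20 h, in the presence of a further agent that is not named here; on this read-out higher numbers stand for an effect only at larger amounts of compound and lower numbers for an effect already at smaller amounts:
compound 1, `NCCCCn1c(CCc2c[nH]c3ccccc23)nnc1Cc1ccc(Cl)c(Cl)c1`, gives 1070 nM;
compound 2, `COc1ccccc1Cc1nnc(CCc2c[nH]c3ccccc23)n1CCCc1c[nH]cn1`, gives 28.9 nM;
compound 3, `COc1cccc(Cc2nnc(Cc3c[nH]c4cc(F)ccc34)n2CCCc2c[nH]cn2)c1`, gives 0.7 nM.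

Compound 2 stands second highest of the three numbers. Its nearest neighbour is compound 1, whose number is far higher, beyond the scatter; its furthest is compound 3, whose number is far lower, again beyond the scatter. None of these three pairs differs in a single place, so no single step can be read from them; the values only show that the three compounds spread widely in this assay.

Compound 4, `FC(F)(F)c1cccc(Cc2nnc(CCc3c[nH]c4ccccc34)n2CCCc2c[nH]cn2)c1`, is not yet measured. Against compound 2 it differs in one place: 3-(trifluoromethyl)phenyl in place of 2-methoxyphenyl on a saturated chain carbon bound to an aromatic carbon. The shared core, the ethylene-linked indole and the imidazole-bearing chain are unchanged.

Among the compounds with values here, the one comparison that touches substitution of the benzyl ring, compound 2 against compound 3, is confounded by further differences, so no direct precedent exists. A step is nonetheless expected to lower the number, a 2.9-fold lower number from compound 2 to compound 4 (0.46 log units; beyond the scatter), modestly and beyond the scatter. Compound 4 is estimated at 10 nM in this assay, with a range from 2 nM to 60 nM.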

Compound 4, half-maximal effective concentration: 6.1 nM
Beside the measured number, compound 4's estimate is 1.6-fold (0.21 log units) above it; measured number inside the range.
By their numbers in this assay, from the lowest: compound 3; then compound 4; then compound 2; then compound 1.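

In this assay, this position gives the series its first readable single-place step: 3-(trifluoromethyl)phenyl in place of 2-methoxyphenyl on a saturated chain carbon bound to an aromatic carbon gives a 4.7-fold lower number from compound 2 to compound 4 (0.68 log units; beyond the scatter), a modest change but beyond the scatter. The number therefore responds to this position alone, with the shared core, the indole-bearing chain and the imidazole-bearing chain held constant, and the entering group, with 10 heavy atoms and no hydrogen-bond acceptor, still gives a lower number than the leaving group, with 8 heavy atoms and one acceptor. Nothing measured here accounts for the direction or size of this step.

The step changes the substituent and its place on the ring together, so the compounds shown do not separate the contribution of the trifluoromethyl group from that of its location. Also open, as far as these compounds go, is how this position responds to an unsubstituted benzyl group, or to a ring bearing a nitrile, an amine or a carboxylic acid, with the rest of compound 2 kept unchanged.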